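Trading the Dichlorophenoxy Arm for a Single Fluorine

The source may report more compounds than this note shows. Statements on the series, on what has been measured and on what is new or still open speak of the compounds shown alone.

Within the data shown here, compound 1 `C=CC(=O)NCc1coc(-c2c(N)ncnc2Nc2ccc(Oc3cc(Cl)ccc3Cl)c(Cl)c2)n1` was tested in an in vitro ADME assay on microsomes from liver (Rattus norvegicus) for metabolic stability, tested at 5 uM (a higher number here means that the compound lasts longer, a lower number that the compound disappears faster), and gives 0.85 h, the higher of the two numbers measured so far. Compound 2 `C=CC(=O)NCc1coc(-c2c(N)ncnc2Nc2ccc(Oc3cccnc3)c(Cl)c2)n1` gives 0.15 h in this assay. Among the measured compounds shown here, the only measured step, a 5.7-fold lower number from compound 1 to compound 2 (0.75 log units; beyond the scatter), is a modest loss that lies beyond the scatter. Compound 3 `C=CC(=O)NCc1coc(-c2c(N)ncnc2Nc2ccc(F)c(Cl)c2)n1` has not yet been measured in this assay. It differs from compound 1 by fluoro in place of 2,5-dichlorophenoxy on an aromatic carbon: the whole 2,5-dichlorophenoxy group is gone and a single fluorine takes its place. The step from compound 1 to compound 2 bears on this only loosely, since it changed the same place but kept an aromatic ring on the oxygen, whereas compound 3 keeps no ring there. On that slim basis a downward step is expected. Compound 3 is therefore expected to give 0.4 h in this assay, within a range from 0.15 h to 1.1 h, which means an expected 2.1-fold lower number from compound 1 to compound 3 (0.33 log units; beyond the scatter).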

Compound 3, half-life: 0.4 h
Compound 3: the middle estimate sits on the measured number at the digits printed, and the stated range covers the measured number.
By their numbers in this assay, from the lowest: compound 2; then compound 3; then compound 1.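

Losing the whole ring at this position does not produce the lowest number of the three. In this assay the single fluorine falls between the two compounds that carry an aromatic ring on the oxygen, with a 2.1-fold lower number from compound 1 to compound 3 (0.33 log units; beyond the scatter) on one side and a 2.7-fold higher number from compound 2 to compound 3 (0.43 log units; beyond the scatter) on the other. So having a ring arm here does not by itself set the direction of the change: 2,5-dichlorophenoxy stands above fluoro, while (pyridin-3-yl)oxy stands below it. Nothing measured here explains this order.

From the compounds shown here alone, whether a small group other than fluoro, such as methoxy or an amine, would land near compound 3 remains open. So does the question of where a saturated ring such as morpholine on this same carbon would fall among the three compounds.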